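Indole core series: methyl to hydrogen on the ring nitrogen

The compounds below may be only part of what the source reports. "The series", "measured", "known", "first", "only" and "open" are said of these compounds alone.

Three compounds of this shared core have numbers in an assay on isolated protein for inhibition of Aromatase (Homo sapiens), read by fluorescence, using NADPH, with a stated time of 30 min; on this read-out higher numbers stand for weaker inhibition and lower numbers for stronger inhibition. Compound 1 `N#Cc1ccc2[nH]c(-c3ccccc3)cc2c1` gives 3340 nM. Compound 2 `Cc1ccccc1-c1cc2cc([N+](=O)[O-])ccc2[nH]1` gives 6870 nM. Compound 3 `Cn1c(-c2ccccc2)cc2cc([N+](=O)[O-])ccc21` gives 3880 nM, which stands second highest of the three; its nearest neighbour is compound 1, whose number lies within the scatter of it, and its furthest is compound 2, also within the scatter. No pair among these three differs in one place only, so no single step can be read from the measured set, and the three numbers sit close together.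

Compound 4 `O=[N+]([O-])c1ccc2[nH]c(-c3ccccc3)cc2c1` awaits measurement in this assay. It differs from compound 3 by hydrogen in place of methyl on an aromatic nitrogen, the nitrogen of a five-membered aromatic ring with 1 nitrogen, part of a fused system of two rings, next to the ring atom that bears a phenyl group. The measured compounds give no direct guide to this change; the step from compound 3 to compound 4 is expected to be a 1.0-fold higher number from compound 3 to compound 4 (0.01 log units; within the scatter), none beyond the scatter. Compound 4 is therefore estimated at 4000 nM, within a range of 1500 nM to 11000 nM.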

Compound 4, half-maximal inhibitory concentration: 9000 nM
Beside the measured number, compound 4's estimate is 2.3-fold (0.35 log units) below it, and the stated range covers the measured number.
By their numbers in this assay, from the lowest: compounds 1, 3, 2 and 4 (each within the scatter of the next, the first and the last beyond it).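

In this assay, the ring nitrogen now has a readable step: a 2.3-fold higher number from compound 3 to compound 4 (0.37 log units; beyond the scatter), so within this pair, methyl on that aromatic nitrogen goes with stronger inhibition than hydrogen does. With hydrogen on the ring nitrogen, nitro in place of cyano on an aromatic carbon gives a 2.7-fold higher number from compound 1 to compound 4 (0.43 log units; beyond the scatter), whereas hydrogen in place of methyl on an aromatic carbon gives a 1.3-fold higher number from compound 2 to compound 4 (0.12 log units; within the scatter), so only the first two of these changes register beyond the scatter. No measurement at hand bears on what lies behind these steps.

On these data alone, whether methyl on the ring nitrogen has the same effect with cyano in place of nitro remains open. Also open, as far as these compounds go, is how an ethyl group or a longer chain on that nitrogen would read, and how an amine or a carboxylic acid would read in place of the nitro group.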